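The source may hold more compounds than are shown below. What is called first, only, known or untested is meant among the compounds shown, and "the series" means these compounds.

Working notes on the series. Compound 1 `CC(C)[S+]([O-])CCCCN=C=S` gives 10400 nM in an ADME assay on Vero cells (Chlorocebus sabaeus) for cytotoxicity, read by MTT assay, with a stated time of 72 h; a higher number here means a weaker inhibitor, a lower number a stronger inhibitor. Compound 3 `CC(C)[S+]([O-])CCCCCN=C=S` carries the change a group of 4 heavy atoms (2 carbon, 1 nitrogen, 1 sulfur; no ring) in place of a group of 3 heavy atoms (1 carbon, 1 nitrogen, 1 sulfur; no ring), on a saturated chain carbon, four bonds along the chain from a sulfur relative to compound 1; in this assay compound 3 gives 10300 nM; the step of a 1.0-fold lower number from compound 1 to compound 3 (0.00 log units; within the scatter). Compound 2 `[O-][S+](CCCCCN=C=S)Cc1ccccc1` gives 5850 nM in this assay; the difference between the cores of compound 1 and compound 2 is not broken down here, and the values of compound 2 and compound 3 lie within the scatter of each other. Compound 4 `[O-][S+](CCCCCCN=C=S)Cc1ccccc1` is not yet measured and differs from compound 2 by a group of 4 heavy atoms (2 carbon, 1 nitrogen, 1 sulfur; no ring) in place of a group of 3 heavy atoms (1 carbon, 1 nitrogen, 1 sulfur; no ring), on a saturated chain carbon, five bonds along the chain from a sulfur. This is the same kind of change as that from compound 1 to compound 3, though the place here is five bonds along the chain from a sulfur rather than four. In this assay a step of about a 1.0-fold higher number from compound 2 to compound 4 (0.01 log units; within the scatter) is expected, because the step of a 1.0-fold lower number from compound 1 to compound 3 (0.00 log units; within the scatter) lay within the scatter. Compound 4 is therefore estimated at 6000 nM, between 3000 nM and 12000 nM.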

Compound 4, half-maximal inhibitory concentration: 4330 nM
Beside the measured number, compound 4's estimate is 1.4-fold (0.14 log units) above it, within the range that was stated.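

In this assay the new step reads a 1.4-fold lower number from compound 2 to compound 4 (0.13 log units; within the scatter) and stays within the scatter. Set beside the earlier step, the same change shows no difference between the two cores: the same change on two cores in this assay, a 1.0-fold lower number (0.00 log units; within the scatter) from compound 1 to compound 3 and a 1.4-fold lower number (0.13 log units; within the scatter) from compound 2 to compound 4, 1.3-fold (0.13 log units) apart, within the scatter of two such steps. This supports carrying the change from one core to the other as a step within the scatter, but it rests on two pairs only, and the place differs, four bonds along the chain from a sulfur in one and five in the other, so it shows neither a rule for other cores nor a trend with chain length. The compounds shown leave open whether a longer chain than that of compound 4 would give a step beyond the scatter. They also leave open how an amine or a carboxylic acid would read in place of the changed group.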